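Carbamoyl in Place of Methoxy on the Shared Core

This account rests on a few compounds, and the source may have more. Where it says the series, first, only, none or still open, it means among the compounds named here.

Compound 3 `CCCCNc1nc(N)nc2cc(OC)ccc12` stands second highest of three numbers in an ADME assay on HEK293 cells for agonist activity at Toll-like receptor 8 (Homo sapiens), read by a luciferase reporter, with a stated time of 6 h (on this read-out higher numbers stand for an effect only at larger amounts of compound and lower numbers for an effect already at smaller amounts), giving 0.3 uM. Compound 1 `CCCCCNc1nc(N)nc2ccccc12` gives 0.1 uM, and compound 2 `CC(C)CCNc1nc(N)nc2ccccc12` gives 2.11 uM. For the measured compounds named here, the only measured step, a 21-fold higher number from compound 1 to compound 2 (1.32 log units; beyond the scatter), concerns the saturated chain, not the aromatic ring. Compound 4 `CCCCNc1nc(N)nc2cc(C(N)=O)ccc12` differs from compound 3 by carbamoyl in place of methoxy on an aromatic carbon. Going by the values given here, no measured step touches a substituent on the aromatic ring, so that chain step offers no direct guide, and the exchange of one small uncharged group for another is expected to move the number in this assay only modestly, within or near the scatter. Compound 4 is therefore estimated at 0.4 uM, with a range from 0.1 uM to 1.5 uM. This amounts to an expected 1.3-fold higher number from compound 3 to compound 4 (0.12 log units; within the scatter).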

Compound 4, minimum effective concentration: 2 uM
Beside the measured number, compound 4's estimate is 5.0-fold (0.70 log units) below it; the measured number lies above the stated range.
By their numbers in this assay, from the lowest: compound 1; then compound 3; then compounds 4 and 2 (each within the scatter of the next).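

In this assay carbamoyl in place of methoxy gives a 6.7-fold higher number from compound 3 to compound 4 (0.82 log units; beyond the scatter) on this aromatic carbon, so the number responds to the group held here and not only to the saturated chain. The entering group has one hydrogen-bond donor where the leaving group has none, but this single pair cannot tie the step to that difference. On these data alone, whether an amine, a carboxylic acid or a hydroxyl on this carbon would stand nearer compound 3 or compound 4 remains open, as does whether the step would hold with a pentyl chain. Nothing measured here accounts for the step.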